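Methyl in Place of Bromo on Two Different Cores

The source may hold more compounds than are shown below. What is called first, only, known or untested is meant among the compounds shown, and "the series" means these compounds.

In a functional assay on MCF7 cells (Homo sapiens) for antiproliferative activity, read by sulforhodamine B assay, with a stated time of 72 h, tested at 30 uM (on this read-out higher numbers stand for a weaker effect at the one concentration tested and lower numbers for a stronger effect), compound 2 `COc1cc(Br)cc(/C=C/C(=O)c2ccc(Br)cc2)c1O` gives 48.3% and compound 1 `COc1cc(Br)cc(/C=C/C(=O)c2ccc(C)cc2)c1O` gives 61.5%. The change between them, (methyl in place of bromo on an aromatic carbon), made a step of a number 13.2 percentage points higher from compound 2 to compound 1 (beyond the scatter). Compound 3 `N#CC1=C(N)Oc2ccc(Br)cc2C1CC(=O)c1ccc(Br)cc1` rests on a different core; the difference between the two cores is not broken down here. In this assay compound 3 gives 34.2%, the lowest of the three values. Compound 4 `Cc1ccc(C(=O)CC2C(C#N)=C(N)Oc3ccc(Br)cc32)cc1` carries the same change on the core of compound 3, namely (methyl in place of bromo on an aromatic carbon), a change that occurs twice among the compounds shown. Among the measured compounds shown here, because the measured step of a number 13.2 percentage points higher from compound 2 to compound 1 (beyond the scatter) is the only guide, the step to compound 4 is expected to be of similar size, a number 11.8 percentage points higher from compound 3 to compound 4 (beyond the scatter). Compound 4 is therefore estimated at 46%, within a range from 33% to 60%.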

Compound 4, a percentage reported as activity, at one concentration (the size of the read-out at that concentration, not a potency): 32.3%
Beside the measured number, compound 4's estimate is 13.7 percentage points above it, and the stated range ends above it.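

In this assay the change from 4-bromophenyl to 4-methylphenyl on the core of compound 3 gives a number 1.9 percentage points lower from compound 3 to compound 4 (within the scatter) and does not repeat the step seen on the core of compound 1. The outcome of this change therefore depends on the core in these two pairs: the same change on two cores in this assay, a number 13.2 percentage points higher (beyond the scatter) from compound 2 to compound 1 and a number 1.9 percentage points lower (within the scatter) from compound 3 to compound 4, 15.1 percentage points apart, beyond the scatter of two such steps. This shows that the step measured on one core could not be carried over to the other, but it does not show which part of the cores is responsible or how the change would behave on a further core.

The compounds shown leave open how an amine, a carboxylic acid or a longer chain in this place would read on either core. They also leave open whether such groups would separate the two cores as these two pairs do.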